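Porcupine series: notes on compounds 1 to 4

This account rests on a few compounds, and the source may have more. Where it says the series, first, only, none or still open, it means among the compounds named here.

Measured so far:
- compound 1 `O=C(CNC(=O)c1nn(-c2ccccc2)c(=O)c2ccccc12)Nc1nc2ccc(F)cc2s1` — in an assay on L cells for inhibition of Protein-serine O-palmitoleoyltransferase porcupine (Mus musculus), read by reporter gene assay, with a stated time of 24 h (on this read-out higher numbers stand for an effect only at larger amounts of compound and lower numbers for an effect already at smaller amounts), compound 1 gives 470 nM
- compound 2 `COc1ccc2nc(NC(=O)CNC(=O)c3nn(-c4ccccc4OC)c(=O)c4ccccc34)sc2c1` — in this assay compound 2 gives 90 nM
- compound 3 `CN(C)c1ccc(NC(=O)CSc2nc3c(c(=O)n2-c2ccccc2)SCC3)cc1` — in this assay compound 3 returns only a limit of the assay, > 1000 nM, not a number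

Compound 3 therefore stands at the edge of what this assay can report: the read-out is a limit, (the limit of > 1000 nM in this assay, at which 1 of the 3 values shown sits), and no number can be put beside it. Going by the values given here, no two measured compounds differ in a single place, so no single step has been measured; compounds 1 and 2 share a different core and differ from compound 3 in several places at once.

Compound 4 `CC(=O)c1ccc(NC(=O)CSc2nc3c(c(=O)n2-c2ccccc2)SCC3)cc1` is compound 3 with acetyl in place of dimethylamino on an aromatic carbon. Since compound 3 sits at a limit, the move to compound 4 is expected to stay within the scatter, with no clear direction, a step that the limit leaves unreadable from compound 3 to compound 4. For compound 4 in this assay the estimate is 2000 nM, in a range from 600 nM to 8000 nM, and it is expected that the assay may again return only a limit.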

Compound 4, half-maximal effective concentration: > 1000 nM
Compound 4: only a limit was reported (the forecaster's own chance of this, stated with the estimate: 60%); the middle value is on the limit's open side.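

No step can be read between compound 3 and compound 4, since each returns only a limit: the limit of > 1000 nM in this assay, at which 2 of the 4 values shown sit.
Going by these compounds, whether acetyl and dimethylamino on this aromatic carbon differ at all in this assay stays open, since neither compound gives a number there.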